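Changing the Sulfur Substituent of Compound 1

The compounds below may be only part of what the source reports. "The series", "measured", "known", "first", "only" and "open" are said of these compounds alone.

Three compounds have been measured in a functional assay on DU-145 cells (Homo sapiens) for inhibition, read by trypan blue exclusion, with a stated time of 96 h; on this read-out lower numbers stand for stronger inhibition of growth and higher numbers for weaker inhibition of growth:

compound 1, `Cc1ccc(S/C(=C/c2sccc2C)C(=O)c2ccc(Br)cc2)cc1`, gives 50000 nM
compound 2, `Cc1ccc(S/C(=C/c2ccc(Cl)cc2)C(=O)c2ccc(Br)cc2)cc1`, gives 10000 nM
compound 3, `Cc1ccc(S/C(=C/c2c(O)cc(O)cc2O)C(=O)c2ccc(Br)cc2)cc1`, gives only the limit of the assay, > 100000 nM

Compound 1 thus holds the highest of the two numbers, its nearest neighbour being compound 2, with a 5.0-fold lower number from compound 1 to compound 2 (0.70 log units; beyond the scatter). The third value is a limit rather than a number, as stated by the limit of > 100000 nM in this assay, at which 1 of the 3 values shown sits.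

Compound 4, `Cc1ccsc1/C=C(/SCc1ccc(Cl)cc1)C(=O)c1ccc(Br)cc1`, has not yet been measured. It differs from compound 1 in one place: 4-chlorobenzyl in place of 4-methylphenyl on a sulfur.

All three measured steps, a 5.0-fold lower number from compound 1 to compound 2 (0.70 log units; beyond the scatter), an at least 2.0-fold higher number from compound 1 to compound 3 (0.30 log units; that floor lies within the scatter) and an at least 10-fold higher number from compound 2 to compound 3 (1.00 log units; beyond the scatter), alter the group on a double-bonded chain carbon, and none alters the group on the sulfur. For the measured compounds named here, no measured step therefore bears on the change from compound 1 to compound 4, and nothing in these data speaks for a shift in either direction. Compound 4 is accordingly expected to show no change at the digits printed from compound 1 to compound 4 (within the scatter), a step not beyond the scatter. The estimate for compound 4 in this assay is 50000 nM, within a range from 15000 nM to 150000 nM.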

Compound 4, concentration for 50% growth inhibition: 25000 nM
Estimate against measurement, compound 4: 2.0-fold (0.30 log units) above; the measured number falls inside the stated range.
By their numbers in this assay, from the lowest: compound 2; then compounds 4 and 1 (each within the scatter of the next). At a limit, above all of these: compound 3.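

In this assay, for the compounds shown here, the sulfur position is read for the first time: 4-chlorobenzyl in place of 4-methylphenyl on a sulfur gives a 2.0-fold lower number from compound 1 to compound 4 (0.30 log units; within the scatter). Going by these compounds alone, the number at this position thus stays within the scatter when the group on the sulfur is exchanged, a tolerance the earlier steps, all made on the double-bonded chain carbon, could not show. The exchange brings in the chlorine and the benzyl form together, so their separate contributions cannot be told apart, and nothing measured here explains the result.

From the compounds shown here alone, it remains open whether an amine, a carboxylic acid or a longer chain on the sulfur would also stay within the scatter. Going by these compounds, it is equally open whether 4-chlorobenzyl on the sulfur would give a similar step with 4-chlorophenyl on the double-bonded chain carbon.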